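The source may hold more compounds than are shown below. What is called first, only, known or untested is meant among the compounds shown, and "the series" means these compounds.

Measured in a toxicity assay on KB cells (Homo sapiens) for cytotoxicity, read by fluorescence, with a stated time of 3 days; on this read-out lower numbers stand for an effect already at smaller amounts and higher numbers for an effect only at larger amounts of compound:
- compound 1 `CCCCOC(=O)CNC(=O)[C@H](CSc1ccc([N+](=O)[O-])cc1[N+](=O)[O-])NC(=O)CC[C@H](NC(=O)OC)C(=O)OCCCC`: > 300 uM (a limit of the assay, not a number)
- compound 2 `CCCCOC(=O)CNC(=O)[C@H](CSc1ccc([N+](=O)[O-])cc1[N+](=O)[O-])NC(=O)CC[C@H](NC(=O)C(C)(C)C)C(=O)OCCCC`: 83.4 uM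
- compound 3 `CCCCOC(=O)CNC(=O)[C@H](CSc1ccc([N+](=O)[O-])cc1[N+](=O)[O-])NC(=O)CC[C@H](NC(=O)CCc1c[nH]c2ccccc12)C(=O)OCCCC`: 26 uM

Among the values that are actual numbers, compound 3 stands lowest at 26 uM, and its nearest neighbour is compound 2 at 83.4 uM. The gap between them is a 3.2-fold lower number from compound 2 to compound 3 (0.51 log units; beyond the scatter).

Compound 4 `CCCCOC(=O)CNC(=O)[C@H](CSc1ccc([N+](=O)[O-])cc1[N+](=O)[O-])NC(=O)CC[C@H](NC(=O)C(C)C)C(=O)OCCCC` keeps the shared core and changes a single group: isopropyl in place of 2-(1H-indol-3-yl)ethyl on a carbonyl carbon. In words, this is isopropyl in place of 2-(1H-indol-3-yl)ethyl on a carbonyl carbon.

The measured steps at this same carbonyl carbon bear on the change. They are an at least 3.5-fold lower number from compound 1 to compound 2 (0.55 log units; beyond the scatter), an at least 11-fold lower number from compound 1 to compound 3 (1.06 log units; beyond the scatter) and, most directly, a 3.2-fold lower number from compound 2 to compound 3 (0.51 log units; beyond the scatter). The isopropyl group of compound 4 resembles the tert-butyl group of compound 2 far more than the group it replaces, so compound 2 at 83.4 uM is the best guide.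

this assay is therefore expected to show a modest to large rise in the number, estimated as a 3.8-fold higher number from compound 3 to compound 4 (0.59 log units; beyond the scatter). A result at the limit of > 300 uM in this assay, at which 1 of the 3 values shown sits, remains possible for compound 4. The estimate for compound 4 is 100 uM, with an expected range from 45 uM to 250 uM.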

Compound 4, concentration for half-maximal effect: > 300 uM
Compound 4: a limit, no number (the forecaster's own chance of this, stated with the estimate: 15%); middle value at least 3.0-fold (0.47 log units) from the limit.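

In this assay, replacing the 2-(1H-indol-3-yl)ethyl group on this carbonyl carbon with isopropyl gives an at least 11-fold higher number from compound 3 to compound 4 (1.06 log units; beyond the scatter), and going from tert-butyl to isopropyl, a difference of a single methyl, gives an at least 3.5-fold higher number from compound 2 to compound 4 (0.55 log units; beyond the scatter), so a small change among saturated carbon groups at this position is enough to move the read-out beyond the scatter. Across the three compounds with a carbon group here, compound 3, compound 2 and compound 4, the number rises as the group gets smaller, and none of them goes against this order, though compound 4 fixes only one end of it. Compound 1 and compound 4 both stand at a limit of the assay, and the step between them cannot be read: the limit of > 300 uM in this assay, at which 2 of the 4 values shown sit.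

The compounds shown leave open whether the lower number of compound 3 follows from the count of heavy atoms alone or needs the aromatic rings, a question that a plain phenyl group or a longer saturated chain on this carbonyl carbon would address. They also leave open how an amine or a carboxylic acid at the end of such a chain would read in this assay.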